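Extending Methyl to Ethyl on a Shared Core

The compounds below may be only part of what the source reports. "The series", "measured", "known", "first", "only" and "open" are said of these compounds alone.

Compound 1 `COc1ccc(-c2cc(-c3ccc([N+](=O)[O-])cc3)on2)cc1`, compound 2 `Oc1ccc(-c2cc(-c3ccc(O)cc3)on2)cc1` and compound 3 `Cc1c(-c2ccc(O)cc2)noc1-c1ccc(O)cc1` share one core and were tested in a functional assay on MCF7 cells (Homo sapiens) for antiproliferative activity, read by cell counting, with a stated time of 5 days; on this read-out lower numbers stand for stronger inhibition and higher numbers for weaker inhibition. In this assay compound 1 gives a limit of the assay rather than a number, > 100000 nM. Compound 2 gives 5200 nM, and compound 3 gives 48000 nM, the highest of the two numbers obtained. Within the data shown here, the single measured step between them, a 9.2-fold higher number from compound 2 to compound 3 (0.97 log units; beyond the scatter), was methyl in place of hydrogen on an aromatic carbon. Compound 4 `CCc1c(-c2ccc(O)cc2)noc1-c1ccc(O)cc1` carries the change (methyl in place of hydrogen on a saturated chain carbon bound to an aromatic carbon), which read one bond further out is methyl to ethyl. That earlier step is the only one bearing on it, so a further rise, or none beyond the scatter, is expected. Compound 4 is estimated to give 70000 nM, between 25000 nM and 200000 nM, an expected step of a 1.5-fold higher number from compound 3 to compound 4 (0.16 log units; within the scatter).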

Compound 4, half-maximal inhibitory concentration: 9800 nM
Compound 4: the middle estimate sits 7.1-fold (0.85 log units) above what was measured; the whole stated range lies above it.
By their numbers in this assay, from the lowest: compounds 2 and 4 (each within the scatter of the next); then compound 3. At a limit, above all of these: compound 1.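

In this assay, extending methyl to ethyl at this place does not continue the earlier rise but reverses it, with a 4.9-fold lower number from compound 3 to compound 4 (0.69 log units; beyond the scatter), so the number does not climb steadily as the group grows. Set against hydrogen, the ethyl group gives a 1.9-fold higher number from compound 2 to compound 4 (0.28 log units; within the scatter), so of these two groups only methyl stands apart from hydrogen here. Nothing shown gives a reason for this reversal.

A longer chain such as propyl could follow ethyl or methyl here, and the three groups shown cannot tell which. On these data alone, how an amine or a carboxylic acid at this place would read also stays open.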